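This account rests on a few compounds, and the source may have more. Where it says the series, first, only, none or still open, it means among the compounds named here.

Measured compounds:

- compound 1 `CCOC(=O)c1oc2ccc(NS(=O)(=O)c3ccc(Cl)cc3)cc2c1C`; in a functional assay on HCT-116 cells (Homo sapiens) for inhibition, read by MTT assay, with a stated time of 72 h (a higher number here means a weaker inhibitor, a lower number a stronger inhibitor), compound 1 gives > 40000 nM, which is a limit of the assay and not a number.
- compound 2 `CCOC(=O)c1oc2ccc(N(Cc3ccccc3)S(=O)(=O)c3cccc(Br)c3)cc2c1C`; compound 2 gives > 40000 nM, again a limit of the assay.
- compound 3 `CCOC(=O)c1oc2ccc(N(Cc3ccc(Cl)cc3)S(=O)(=O)c3ccc(Cl)cc3)cc2c1C`; compound 3 gives 9640 nM.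

Among the compounds with values here, compound 3 therefore holds the only real number in the set; the other two sit at the limit of > 40000 nM in this assay, at which 2 of the 3 values shown sit. Within the data shown here, the one measured step that reaches compound 3 is an at least 4.1-fold lower number from compound 1 to compound 3 (0.61 log units; beyond the scatter), so attaching the 4-chlorobenzyl group to the sulfonamide nitrogen brought the value down from the limit.

Compound 4 `CCOC(=O)c1oc2ccc(N(C(C)C)S(=O)(=O)c3ccc(Cl)cc3)cc2c1C` differs from compound 3 by isopropyl in place of 4-chlorobenzyl on a sulfonamide nitrogen. This change takes away most of the group whose arrival gave the only measured gain, and puts a smaller chain in its place. Given that compound 1 without a group on that nitrogen gives > 40000 nM, a step upward in this assay is expected, though probably not all the way back to the limit. Compound 4 is estimated at 25000 nM, with a range from 7000 nM to 60000 nM, meaning an expected step of a 2.6-fold higher number from compound 3 to compound 4 (0.41 log units; beyond the scatter).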

Compound 4, half-maximal inhibitory concentration: > 40000 nM
Compound 4: a limit, no number (the forecaster's own chance of this, stated with the estimate: 45%); at least 1.6-fold (0.20 log units) between middle value and limit.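

In this assay, isopropyl in place of 4-chlorobenzyl on the sulfonamide nitrogen gives an at least 4.1-fold higher number from compound 3 to compound 4 (0.61 log units; beyond the scatter), so among the compounds shown, a carbon group on that nitrogen does not by itself bring the value down from the limit. The step from compound 1 to compound 4 cannot be read, as both values are limits, so nothing can be said about isopropyl against hydrogen. Compound 3 remains the only compound in the set with a real number: the limit of > 40000 nM in this assay, at which 3 of the 4 values shown sit.

On these data alone, it remains open whether the ring of the 4-chlorobenzyl group or its chlorine accounts for the gain, and a plain benzyl on this nitrogen, with the rest of compound 3 unchanged, would separate the two. A longer chain such as n-butyl, or a phenethyl group, would show whether the distance from the nitrogen to a ring matters as well.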